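Chloro replacing cyano: the step from compound 3 to compound 4

The source may hold more compounds than are shown below. What is called first, only, known or untested is meant among the compounds shown, and "the series" means these compounds.

The series holds three measured compounds, compound 1 `COc1cc(C(=O)/C=C(\C)c2ccncc2)cc(OC)c1OC`, compound 2 `CC(C)(C)c1ccc(C(=O)/C=C/c2ccncc2)cc1` and compound 3 `N#Cc1ccc(C(=O)/C=C/c2ccncc2)cc1`. In a functional assay with Rattus norvegicus as the target (on this read-out lower numbers stand for stronger inhibition and higher numbers for weaker inhibition), compound 1 gives only a limit, > 100000 nM, as stated by the limit of > 100000 nM in this assay, at which 1 of the 3 values shown sits. Compound 2 gives 47000 nM and compound 3 gives 123000 nM, the highest of the two numbers. Among the compounds with values here, the one measured step is a 2.6-fold higher number from compound 2 to compound 3 (0.42 log units; beyond the scatter). Compound 4 `O=C(/C=C/c1ccncc1)c1ccc(Cl)cc1` differs from compound 3 by chloro in place of cyano on an aromatic carbon. That single step, cyano replacing tert-butyl, moved to a higher number; with cyano now removed, a modest move back toward a lower number is expected for compound 4, a 2.1-fold lower number from compound 3 to compound 4 (0.31 log units; beyond the scatter). Compound 4 is therefore estimated at 60000 nM, within 25000 nM to 150000 nM.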

Compound 4, half-maximal inhibitory concentration: 60000 nM
Estimate against measurement, compound 4: no gap at the digits printed; the measured number falls inside the stated range.
By their numbers in this assay, from the lowest: compounds 2 and 4 (each within the scatter of the next); then compound 3.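

In this assay, three groups can now be compared on this aromatic carbon, para to a large group. Chloro in place of cyano gives a 2.1-fold lower number from compound 3 to compound 4 (0.31 log units; beyond the scatter), whereas chloro in place of tert-butyl gives a 1.3-fold higher number from compound 2 to compound 4 (0.11 log units; within the scatter), so chloro and tert-butyl cannot be told apart here and cyano alone stands apart, with the highest number. Nothing shown gives a cause for these steps.

Open, going by these compounds, is how an amine or a carboxylic acid would read at this position, and whether any group there gives a number well below that of compound 2.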